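Swapping the aryl group on the piperazine of a xanthine sulfonamide

The compounds below may be only part of what the source reports. "The series", "measured", "known", "first", "only" and "open" are said of these compounds alone.

Compound 1 `CCCn1c(=O)[nH]c2nc(-c3ccc(S(=O)(=O)N4CCN(c5ccccc5Br)CC4)cc3)[nH]c2c1=O` — 0.137 nM
Compound 2 `CCCn1c(=O)[nH]c2nc(-c3ccc(S(=O)(=O)N4CCN(c5ccc(C)cc5)CC4)cc3)[nH]c2c1=O` — 0.706 nM

Two compounds share a core and differ only in the aryl group carried on an amine nitrogen in a ring. In an assay on CHO cells for displacement of a labelled ligand from adenosine receptor A2b (Homo sapiens), read by scintillation counting, with a stated time of 75 min, in the presence of a further agent that is not named here (a lower number here means a stronger inhibitor, a higher number a weaker inhibitor), compound 1 gives 0.137 nM. Compound 2, with a 4-methylphenyl in place of the 2-bromophenyl, gives 0.706 nM, and the step of a 5.2-fold higher number from compound 1 to compound 2 (0.71 log units; beyond the scatter) is beyond the scatter. Compound 2 therefore stands with the higher of the two numbers shown, the weaker of the pair.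

Compound 3 `CCCn1c(=O)[nH]c2nc(-c3ccc(S(=O)(=O)N4CCN(c5cccc(F)c5)CC4)cc3)[nH]c2c1=O` is not yet measured. It differs from compound 2 by 3-fluorophenyl in place of 4-methylphenyl on an amine nitrogen in a ring. Going by the values given here, only one measured step bears on this place, a 5.2-fold higher number from compound 1 to compound 2 (0.71 log units; beyond the scatter), and it concerns a different pair of groups, so it gives direction only loosely: a halogen-bearing phenyl gave a lower number than the methyl-bearing one. The step from compound 2 to compound 3 is expected to be a 1.8-fold lower number from compound 2 to compound 3 (0.25 log units; within the scatter), a modest move toward a lower number with wide uncertainty. Compound 3 is thus estimated at 0.4 nM, with a range from 0.12 nM to 1.4 nM.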

Compound 3, inhibition constant: 0.632 nM
Beside the measured number, compound 3's estimate is 1.6-fold (0.20 log units) below it; the range from low to high includes it.
By their numbers in this assay, from the lowest: compound 1; then compounds 3 and 2 (each within the scatter of the next).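

In this assay, replacing 4-methylphenyl with 3-fluorophenyl on the amine nitrogen in the ring yields a step within the scatter (a 1.1-fold lower number from compound 2 to compound 3 (0.05 log units; within the scatter)), so these two groups cannot be told apart here, although one carries a methyl and the other a fluorine. The first pair alone left room for the idea that a halogen on the phenyl might be enough for a low number, but compound 3 goes against this: it carries a halogen, yet the step from the 2-bromophenyl is beyond the scatter (a 4.6-fold higher number from compound 1 to compound 3 (0.66 log units; beyond the scatter)), and compound 1 stands alone with the lowest number of the three. Nothing available here explains why the numbers fall as they do.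

The 2-bromophenyl and the 3-fluorophenyl differ in both the halogen and its place on the phenyl ring, so these compounds cannot show which of the two changes accounts for the step. From the compounds shown here alone, how a 2-fluorophenyl, a 3-bromophenyl or a plain phenyl would read at this place remains open, and those groups would help to separate the two changes.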